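The compounds below may be only part of what the source reports. "The series", "measured", "known", "first", "only" and "open" are said of these compounds alone.

In a functional assay on C6 cells (Rattus norvegicus) for cytotoxicity, read by MTT assay, with a stated time of 24 h (a higher number here means a weaker inhibitor, a lower number a stronger inhibitor), the three measured compounds read as follows:

Compound 1, `Cc1nnc(SCC(=O)N/N=c2/scc(-c3ccc(F)cc3)n2-c2ccccc2)s1`: 27.3 ug/mL
Compound 2, `Cc1nnc(SCC(=O)N/N=c2/scc(-c3ccc(Cl)cc3)n2-c2ccccc2)s1`: 28 ug/mL
Compound 3, `O=C(CSc1nnnn1-c1ccccc1)N/N=c1/scc(-c2ccc(F)cc2)n1-c1ccccc1`: 24.3 ug/mL

Compound 4, `O=C(CSc1nnnn1-c1ccccc1)N/N=c1/scc(-c2ccc(Cl)cc2)n1-c1ccccc1`, has not yet been measured in this assay. It differs from compound 3 by one change, (chloro in place of fluoro on an aromatic carbon).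

The same change has already been made once among the measured compounds, from compound 1 to compound 2: chloro in place of fluoro on an aromatic carbon. There it gave a 1.0-fold higher number from compound 1 to compound 2 (0.01 log units; within the scatter). The two cores on which this change sits are not identical; they differ as 1-phenyl-1H-tetrazol-5-yl in place of 5-methyl-1,3,4-thiadiazol-2-yl on a sulfur, a difference that on its own gave a 1.1-fold lower number from compound 1 to compound 3 (0.05 log units; within the scatter). The place of the change is described in the same words in both pairs, so it is the same change on a related core.

Resting on the step seen from compound 1 to compound 2, a 1.0-fold higher number from compound 1 to compound 2 (0.01 log units; within the scatter), compound 4 is expected to give a 1.0-fold higher number from compound 3 to compound 4 (0.01 log units; within the scatter) relative to compound 3. The estimate for compound 4 in this assay is 25 ug/mL, with a likely range from 15 ug/mL to 42 ug/mL.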

Compound 4, half-maximal inhibitory concentration: > 200 ug/mL
Compound 4 gave a limit, no number (the forecaster's own chance of this, stated with the estimate: 5%); middle value at least 8.0-fold (0.90 log units) away from the limit.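

Compound 4 in this assay gives > 200 ug/mL as a limit of the assay and not a number, so the full size of any step to it stays unknown, and these compounds do not show why the result differs. On the core carrying 1-phenyl-1H-tetrazol-5-yl, chloro in place of fluoro gives an at least 8.2-fold higher number from compound 3 to compound 4 (0.91 log units; beyond the scatter) and so does not repeat the step seen on the core carrying 5-methyl-1,3,4-thiadiazol-2-yl: the same change on two cores in this assay, a 1.0-fold higher number (0.01 log units; within the scatter) from compound 1 to compound 2 and an at least 8.2-fold higher number (0.91 log units; beyond the scatter) from compound 3 to compound 4, at least 8.0-fold (0.90 log units) apart, beyond the scatter of two such steps. Read the other way, 1-phenyl-1H-tetrazol-5-yl in place of 5-methyl-1,3,4-thiadiazol-2-yl on a sulfur gives an at least 7.1-fold higher number from compound 2 to compound 4 (0.85 log units; beyond the scatter) when chloro is present, so in this series neither change can be carried to the other core as a fixed step: the same change on two cores in this assay, a 1.1-fold lower number (0.05 log units; within the scatter) from compound 1 to compound 3 and an at least 7.1-fold higher number (0.85 log units; beyond the scatter) from compound 2 to compound 4, at least 8.0-fold (0.90 log units) apart, beyond the scatter of two such steps.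

On these data alone, it remains open whether this sharp step belongs to chloro alone or would also appear with another group on the same aromatic carbon. A 4-bromophenyl or 4-methylphenyl group on the core of compound 3 would help to separate these two readings.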